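Substituent changes on one aromatic carbon: compounds 1 to 4

A few compounds are considered here, and "the series" means these few. Any claim that something is new, unique, unknown or untested is made for them only; others in the source may bear on it.

Measured so far in a functional assay on MCF7 cells (Homo sapiens), tested at 2.5 uM; a lower number here means a stronger effect, a higher number a weaker effect of the compound at the concentration tested:
compound 1 `CC(C)=CCOc1c(C)c(C)c2c(c1C)CCC(C)(COc1ccc(/C=C3\SC(=O)NC3=O)cc1C)O2`: 89%
compound 2 `CC(C)=CCOc1c(C)c(C)c2c(c1C)CCC(C)(COc1ccc(/C=C3\SC(=O)NC3=O)cc1-c1ccc(F)cc1)O2`: 87%
compound 3 `COc1cc(/C=C2\SC(=O)NC2=O)ccc1OCC1(C)CCc2c(C)c(OCC=C(C)C)c(C)c(C)c2O1`: 95%

Compound 3 holds the highest of the three numbers, yet its gaps to compound 1 and to compound 2 both lie within the scatter, so no order among the three can be read. The next compound, compound 4 `CC(C)=CCOc1c(C)c(C)c2c(c1C)CCC(C)(COc1ccc(/C=C3\SC(=O)NC3=O)cc1Br)O2`, differs from compound 3 in one place: bromo in place of methoxy on an aromatic carbon. For the measured compounds named here, the steps that bear on this position are a number 6 percentage points higher from compound 1 to compound 3 (within the scatter), a number 8 percentage points higher from compound 2 to compound 3 (within the scatter) and a number 2 percentage points lower from compound 1 to compound 2 (within the scatter); every one of them stayed within the scatter, so three different groups there gave much the same read-out. No step beyond the scatter is therefore expected from compound 3 to compound 4, that is a number 5 percentage points lower from compound 3 to compound 4 (within the scatter). Compound 4 is estimated at 90%, with a range from 78% to 100%.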

Compound 4, a percentage reported as activity, at one concentration (the size of the read-out at that concentration, not a potency): 96%
For compound 4 the middle estimate is 6 percentage points below the measured one; the measured number falls inside the stated range.
By their numbers in this assay, from the lowest: compounds 2, 1, 3 and 4 (each within the scatter of the next).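

In this assay bromo on this aromatic carbon gives a number 1 percentage points higher from compound 3 to compound 4 (within the scatter) against methoxy, a number 9 percentage points higher from compound 2 to compound 4 (within the scatter) against 4-fluorophenyl and a number 7 percentage points higher from compound 1 to compound 4 (within the scatter) against methyl, so a fourth group joins the others with no step beyond the scatter. Across these four groups, from a single bromine atom to 4-fluorophenyl, the read-out does not separate at this position. Nothing available explains this flat result.

As far as these compounds go, whether an amine, a carboxylic acid or a longer chain on this carbon would give a step beyond the scatter stays open. So does the effect of changes elsewhere on the shared core.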